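The source may report more compounds than this note shows. Statements on the series, on what has been measured and on what is new or still open speak of the compounds shown alone.

Measured in an ADME assay on HEK-293T cells (Homo sapiens) for antiproliferative activity, read by MTT assay, with a stated time of 48 h, in the presence of a further agent that is not named here; a higher number here means that more compound is tolerated, a lower number that less compound is tolerated:
Compound 1 `Cc1ccc(-c2nn(-c3ccccc3)cc2C(=O)NOCc2ccc(Cl)cc2Cl)cc1` gives 39600 nM.
Compound 2 `COc1ccc(-c2nn(-c3ccccc3)cc2C(=O)NOCc2ccccc2)cc1` gives 201000 nM.
Compound 3 `COc1ccc(-c2nn(-c3ccccc3)cc2C(=O)NOCc2ccccc2F)cc1` gives 24600 nM.

Within the data shown here, compound 3 stands lowest of the three numbers; compound 1 lies within the scatter of it, compound 2 beyond it, the one single-point step here being an 8.2-fold lower number from compound 2 to compound 3 (0.91 log units; beyond the scatter). Compound 4 `COc1ccc(-c2nn(-c3ccccc3)cc2C(=O)NOCc2ccc(Cl)cc2Cl)cc1` differs from compound 3 by 2,4-dichlorophenyl in place of 2-fluorophenyl on a saturated chain carbon bound to an oxygen. Among the measured compounds shown here, no measured step covers this exchange directly; the step from compound 2 to compound 3 concerns the same position but a different group. Compound 1 also carries the 2,4-dichlorobenzyl group and gives 39600 nM, within the scatter of compound 3. Compound 4 is therefore expected near 35000 nM, between 15000 nM and 80000 nM. The expected step of a 1.4-fold higher number from compound 3 to compound 4 (0.15 log units; within the scatter) is not expected to exceed the scatter.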

Compound 4, half-maximal cytotoxic concentration: 545000 nM
Compound 4: the middle estimate sits 16-fold (1.19 log units) below what was measured; measured number outside the range, above it.
By their numbers in this assay, from the lowest: compounds 3 and 1 (each within the scatter of the next); then compound 2; then compound 4.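

In this assay, the 2,4-dichlorobenzyl group does not read the same in both cores: methoxy in place of methyl gives a large rise (a 14-fold higher number from compound 1 to compound 4 (1.14 log units; beyond the scatter)). On the saturated chain carbon bound to an oxygen, 2,4-dichlorophenyl reverses the direction set by 2-fluorophenyl (an 8.2-fold lower number from compound 2 to compound 3 (0.91 log units; beyond the scatter)), with rises both against 2-fluorophenyl (a 22-fold higher number from compound 3 to compound 4 (1.35 log units; beyond the scatter)) and against phenyl (a 2.7-fold higher number from compound 2 to compound 4 (0.43 log units; beyond the scatter)). No evidence on the cause of these steps is at hand.

Open, on these data alone, is how a single chloro group on that phenyl ring would read in the methoxy core. Also open, as far as these compounds go, is whether 2-fluorobenzyl behaves alike with methyl in place of methoxy.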